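The source may hold more compounds than are shown below. What is called first, only, known or untested is meant among the compounds shown, and "the series" means these compounds.

Compound 1 (`OC(Cc1ccccc1)c1cccc2[nH]ncc12`): 13%
Compound 2 (`Cc1cc(C(O)Cc2ccccc2)c2cn[nH]c2c1`): 76%

Compound 2 stands highest of the two numbers in an assay for inhibition of Indoleamine 2,3-dioxygenase 1 (Homo sapiens), read by spectrophotometry, with a stated time of 30 min, tested at 10 uM (on this read-out higher numbers stand for more inhibition at the one concentration tested (going by the name of the read-out) and lower numbers for less inhibition), with compound 1 nearest and its number lower beyond the scatter. Compound 3 (`OC(Cc1ccccc1)c1cc(Br)cc2[nH]ncc12`) differs from compound 2 by bromo in place of methyl on an aromatic carbon. For the measured compounds named here, only one measured step touches the same site: a number 63 percentage points higher from compound 1 to compound 2 (beyond the scatter), showing that a substituent at this carbon raises the read-out strongly. Going by the values given here, no measured step tells how bromo compares with methyl there. Compound 3 is therefore expected to retain much of that inhibition, the step of a number 11 percentage points lower from compound 2 to compound 3 (beyond the scatter) estimated to lie within or near the scatter. The estimate for compound 3 is 65%, range 35% to 90%.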

Compound 3, a percentage reported as inhibition, at one concentration (the size of the read-out at that concentration, not a potency): 90%
The estimate for compound 3 lay 25 percentage points below the measured number; measured number inside the range.
By their numbers in this assay, from the lowest: compound 1; then compound 2; then compound 3.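

In this assay, the gain at this aromatic carbon is not confined to methyl: bromo goes further, with a number 14 percentage points higher from compound 2 to compound 3 (beyond the scatter). Measured against hydrogen, bromo gives a number 77 percentage points higher from compound 1 to compound 3 (beyond the scatter), beyond a number 63 percentage points higher from compound 1 to compound 2 (beyond the scatter) seen with methyl. Still open, as far as these compounds go, is where chloro, an amine, a carboxylic acid or a longer chain would fall at this carbon, so no trend across substituents can be drawn from two groups. Also open, from the compounds shown here alone, is whether the gain holds when the hydroxyl or phenyl part of the shared core changes. No evidence on hand bears on the difference between bromo and methyl.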